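Phenyl for cyclopentyl at a stability limit

The compounds below may be only part of what the source reports. "The series", "measured", "known", "first", "only" and "open" are said of these compounds alone.

Measured so far in an ADME assay on microsomes from liver (Rattus norvegicus) for metabolic stability; on this read-out lower numbers stand for a shorter-lived compound and higher numbers for a longer-lived compound:
- compound 1 `O=C1NC(=O)/C(=C/C(c2ccc(-c3ccc4cccc(F)c4c3)[nH]c2=O)C2CC2)O1` gives > 3 h (a limit)
- compound 2 `O=C1NC(=O)/C(=C/C(c2ccc(-c3ccc4cccc(F)c4c3)[nH]c2=O)C2CCCC2)O1` gives > 3 h (a limit)

Compound 2 stands at > 3 h and that is a limit, not a number. Compound 3 `O=C1NC(=O)/C(=C/C(c2ccccc2)c2ccc(-c3ccc4cccc(F)c4c3)[nH]c2=O)O1` carries phenyl in place of cyclopentyl on a saturated chain carbon bound to an aromatic carbon and a double-bonded chain carbon. Among the measured compounds shown here, the one measured change at this carbon is a step that the two limits leave unreadable from compound 1 to compound 2 and, with the limit of > 3 h in this assay, at which 2 of the 2 values shown sit, in view, it offers no size to carry over. The change expected in this assay is a step that the limit leaves unreadable from compound 2 to compound 3 and no direction can be expected beyond the usual scatter. For compound 3 the estimated half-life is 3.5 h within an expected range from 1.5 h to 8 h.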

Compound 3, half-life: > 3 h
Compound 3 gave a limit, no number; the forecaster's own chance of this, stated with the estimate: 60%; the middle value is on the limit's open side.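

In this assay compound 3 gives > 3 h, which is a limit and not a number. Among the compounds shown here, no step among compound 1, compound 2 and compound 3 can be read. As far as these compounds go, whether cyclopropyl, cyclopentyl or phenyl changes the true half-life remains open.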